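Swapping the ring at the sulfonyl end of compound 1

The source may report more compounds than this note shows. Statements on the series, on what has been measured and on what is new or still open speak of the compounds shown alone.

Of the compounds shown here, three that share one core have been measured in a functional assay, read by fluorescence and spectrophotometry, with a stated time of 1 h; a lower number here means that less compound is needed, a higher number that more compound is needed for the effect. Compound 1, `O=S(=O)(/C=C/c1ccc(O)c(O)c1)CC1CCCCC1`, gives 7500 nM in this assay. Compound 2, `O=S(=O)(/C=C/c1ccc(O)c(O)c1)CCCCCCCCO`, gives 6700 nM, and compound 3, `CCCCCCCCCS(=O)(=O)/C=C/c1ccc(O)c(O)c1`, gives 7700 nM. Among these three numbers compound 1 stands second highest, but its nearest neighbour is compound 3 and its furthest is compound 2, and both gaps are within the scatter, so no order among the three can be read from them.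

The unmeasured compound 4, `O=S(=O)(/C=C/c1ccc(O)c(O)c1)CCCC1CCCC1`, differs from compound 1 in one place: 2-cyclopentylethyl in place of cyclohexyl on a saturated chain carbon bound to a sulfonyl sulfur. Within the data shown here, the only measured step that bears on this is the one in the same part of the molecule, the step from compound 2 to compound 3, which gave a 1.1-fold higher number from compound 2 to compound 3 (0.06 log units; within the scatter). That step and the three values together show that changes to the group bound to the sulfonyl sulfur have so far left this assay unmoved.

On this basis no step beyond the scatter is expected for no change at the digits printed from compound 1 to compound 4 (within the scatter). Compound 4 is therefore estimated to give 7500 nM in this assay, with a range from 3500 nM to 16000 nM.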

Compound 4, half-maximal effective concentration: 6300 nM
Compound 4: the middle estimate sits 1.2-fold (0.08 log units) above what was measured; low and high end bracket the measured number.
By their numbers in this assay, from the lowest: compounds 4, 2, 1 and 3 (each within the scatter of the next).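

The swap of cyclohexyl for 2-cyclopentylethyl, on a saturated chain carbon bound to a sulfonyl sulfur, gives in this assay a 1.2-fold lower number from compound 1 to compound 4 (0.08 log units; within the scatter), so a different ring size and a ring set further along the chain leave the number inside the scatter. The comparisons with the open chains read the same way: cyclopentyl in place of hexyl gives a 1.2-fold lower number from compound 3 to compound 4 (0.09 log units; within the scatter), and cyclopentyl in place of 5-hydroxypentyl gives a 1.1-fold lower number from compound 2 to compound 4 (0.03 log units; within the scatter), so with compound 4 a ring at the far end of the group has now been compared directly with open chains, and neither comparison rises above the scatter. Nothing available explains why these groups give such similar numbers.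

Going by these compounds, all four compounds lie within the scatter of one another, so it stays open whether any group at this position can shift the number, for example a terminal amine, a carboxylic acid, a phenyl ring or a much shorter chain such as methyl. On these data alone, the rest of the shared core is the same in all four, so what its other parts contribute in this assay also stays open.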